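From Isopropyl to Butyl on the Shared Core

The source may report more compounds than this note shows. Statements on the series, on what has been measured and on what is new or still open speak of the compounds shown alone.

In a functional assay on brain (Rattus norvegicus, strain Wistar) for inhibition (on this read-out lower numbers stand for stronger inhibition and higher numbers for weaker inhibition), compound 1 (`Cc1[nH]c(=O)n(C)c1-c1ccccc1`) is reported as a limit, > 100000 nM. Compound 2 (`CCCCOc1ccc(-c2c(C)[nH]c(=O)n2C)cc1`), with butoxy in place of hydrogen on an aromatic carbon, gives 5100 nM, a large change: an at least 19-fold lower number from compound 1 to compound 2 (1.29 log units; beyond the scatter). Compound 3 (`CCCCc1ccc(-c2c(C)[nH]c(=O)n2C(C)C)cc1`) gives 10700 nM, the higher of the two measured numbers and the nearer of them to compound 2. Compound 4 (`CCCCc1ccc(-c2c(C)[nH]c(=O)n2CCCC)cc1`) carries butyl in place of isopropyl on an aromatic nitrogen. For the measured compounds named here, the only measured step, an at least 19-fold lower number from compound 1 to compound 2 (1.29 log units; beyond the scatter), concerns an aromatic carbon and gives no size for this change, so no step beyond the scatter is expected in this assay. The expected step is a 1.2-fold lower number from compound 3 to compound 4 (0.08 log units; within the scatter). For compound 4 the estimated value is 9000 nM, with an expected range of 3000 nM to 30000 nM.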

Compound 4, half-maximal inhibitory concentration: 12000 nM
For compound 4 the middle estimate is 1.3-fold (0.12 log units) below the measured one, within the range that was stated.
By their numbers in this assay, from the lowest: compound 2; then compounds 3 and 4 (each within the scatter of the next). At a limit, above all of these: compound 1.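

With butyl in place of isopropyl on the aromatic nitrogen, this assay gives a 1.1-fold higher number from compound 3 to compound 4 (0.05 log units; within the scatter). For the compounds shown here, this is the first measured step at this nitrogen, and it shows that this exchange of one chain for the other leaves the read-out within the scatter, whereas the earlier step concerned an aromatic carbon. Nothing given here accounts for this result. On these data alone, whether an amine, a carboxylic acid or a longer chain on this nitrogen would shift the number beyond the scatter stays open. So does whether the same holds with butoxy instead of butyl on the aromatic carbon.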